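This account rests on a few compounds, and the source may have more. Where it says the series, first, only, none or still open, it means among the compounds named here.

Measured so far:
- compound 1, `Cc1nc(SCC(=O)Nc2nc(-c3ccc(Cl)cc3)cs2)n(Nc2ccccc2)c1C`: 14000 nM
- compound 2, `Cc1ccc(Nn2c(SCC(=O)Nc3nc(-c4ccccc4)cs3)nc(C)c2C)cc1`: 19100 nM

In a functional assay on KM12 cells (Homo sapiens) for antiproliferative activity, read by sulforhodamine B assay, with a stated time of 48 h (on this read-out higher numbers stand for weaker inhibition of growth and lower numbers for stronger inhibition of growth), compound 1 gives 14000 nM, the lowest of the two numbers, while compound 2 gives 19100 nM, and the two lie within the scatter of each other. Compound 3, `COc1ccc(Nn2c(SCC(=O)Nc3nc(-c4ccc(Cl)cc4)cs3)nc(C)c2C)cc1`, is not yet measured. Going from compound 1 to compound 3, the change is methoxy in place of hydrogen on an aromatic carbon, a methoxy in place of hydrogen on an aromatic carbon. Among the measured compounds shown here, no measured pair shows this change, so the step in this assay is expected to stay within the scatter, with no clear direction, giving an estimated no change at the digits printed from compound 1 to compound 3 (within the scatter). Compound 3 is therefore estimated at 14000 nM, with a range from 5000 nM to 40000 nM.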

Compound 3, concentration for total growth inhibition: 11100 nM
Estimate against measurement, compound 3: 1.3-fold (0.10 log units) above, within the range that was stated.
By their numbers in this assay, from the lowest: compounds 3, 1 and 2 (each within the scatter of the next).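

Turning the phenyl of compound 1 into the 4-methoxyphenyl of compound 3 gives the first direct reading of a change at this position: in this assay there is a 1.3-fold lower number from compound 1 to compound 3 (0.10 log units; within the scatter). A methoxy can therefore sit on this ring, para to a large group, without a clear shift in the number, although this rests on a single pair. No measurement shown here offers an explanation for this result. Still open, from the compounds shown here alone, is whether an amine or a carboxylic acid in the same place would shift the number beyond the scatter.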